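The source may hold more compounds than are shown below. What is called first, only, known or untested is meant among the compounds shown, and "the series" means these compounds.

Three compounds that share one core and differ in the group on a saturated ring carbon have been measured so far in an ADME assay on S9 fraction from liver (Homo sapiens) for metabolic stability, with a stated time of 1 h (on this read-out higher numbers stand for a more stable compound and lower numbers for a less stable compound), on the same terms. Compound 1 (`N#Cc1cnc(NCc2cnccc2C(F)(F)F)cc1N[C@H]1CC[C@@H](O)CC1`) carries hydroxy and stands at 33% in this read-out. Compound 2 (`CO[C@H]1CC[C@@H](Nc2cc(NCc3cnccc3C(F)(F)F)ncc2C#N)CC1`) carries methoxy and stands at 19% in this read-out. Compound 3 (`N#Cc1cnc(NCc2cnccc2C(F)(F)F)cc1N[C@H]1CC[C@@H](C(N)=O)CC1`) carries carbamoyl and reaches 90% as the highest of the three, with both gaps to the others beyond the scatter. Compound 4 (`N#Cc1cnc(NCc2cnccc2C(F)(F)F)cc1N[C@H]1CC[C@@H](c2nc[nH]n2)CC1`) has yet to be measured. Its difference from compound 3 is this: 1H-1,2,4-triazol-3-yl in place of carbamoyl on a saturated ring carbon.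

Going by the values given here, three measured steps bear on this change. The data show a number 57 percentage points higher from compound 1 to compound 3 (beyond the scatter) and a number 71 percentage points higher from compound 2 to compound 3 (beyond the scatter) as large changes, and a number 14 percentage points lower from compound 1 to compound 2 (beyond the scatter) as a modest one. The group at this place can therefore shift the read-out strongly in these compounds, but none of them carries an aromatic ring there, so the data do not show how the incoming ring will fare. Compound 3 at 90% leaves more room to fall than to rise, so a moderate drop is expected rather than a gain. The expected step is a number 22 percentage points lower from compound 3 to compound 4 (beyond the scatter) by this estimate. In this assay compound 4 is estimated at 68% with a range from 42% to 90% as the expected span.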

Compound 4, percent of the compound remaining: 13%
The estimate for compound 4 lay 55 percentage points above the measured number; the measured number lies below the stated range.
By their numbers in this assay, from the lowest: compounds 4 and 2 (each within the scatter of the next); then compound 1; then compound 3.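

Going by these compounds alone, until now, carbamoyl was the only group at this saturated ring carbon to stand high in this assay, and the earlier compounds could not tell whether a larger group bearing a ring would keep that standing. The 1H-1,2,4-triazol-3-yl group does not keep it, with a number 77 percentage points lower from compound 3 to compound 4 (beyond the scatter) as the step from carbamoyl, while the steps from the other two groups are a number 6 percentage points lower from compound 2 to compound 4 (within the scatter) and a number 20 percentage points lower from compound 1 to compound 4 (beyond the scatter) in the same read-out, which places the ring level with methoxy and under hydroxy. Carbamoyl and 1H-1,2,4-triazol-3-yl each bring one hydrogen-bond donor and no net charge, so among these four compounds neither count sorts the numbers, and the high value belongs to carbamoyl rather than to the shared core or to this place alone. Nothing available here accounts for the fall.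

The compounds shown leave open whether a carboxylic acid, an amine or a carbamoyl with a methyl on its nitrogen at this ring carbon would stand nearer to carbamoyl or nearer to the triazole. They also leave open whether a different five-membered aromatic ring there would share the low standing of 1H-1,2,4-triazol-3-yl.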